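Notes on the step from compound 2 to compound 3

A few compounds are considered here, and "the series" means these few. Any claim that something is new, unique, unknown or untested is made for them only; others in the source may bear on it.

Values in a functional assay on RAW264.7 cells (Mus musculus) for inhibition; a higher number here means a weaker inhibitor, a lower number a stronger inhibitor:
- Compound 1 `COc1cc(/C=C/C(=O)CC(=O)/C=C/c2ccc(OC(=O)c3ccccc3O)c(OC)c2)ccc1OC(=O)c1ccccc1O`: 6110 nM
- Compound 2 `COc1cc(/C=C/C(=O)CC(=O)/C=C/c2ccc(OC(=O)c3ccccc3O)c(OC)c2)ccc1O`: > 30000 nM

The value of compound 2 is a limit and not a number: > 30000 nM. Compound 3 `COc1cc(/C=C/C(=O)CC(=O)/C=C/c2ccc(OC(=O)c3ccc(-c4ccc(F)cc4F)cc3O)c(OC)c2)ccc1O` carries 2,4-difluorophenyl in place of hydrogen on an aromatic carbon. Going by the values given here, the only measured step, an at least 4.9-fold higher number from compound 1 to compound 2 (0.69 log units; beyond the scatter), is a change at another place, so it bears on this one only loosely. It does show that an added group can separate a measurable value from the limit. A modest move toward a lower number in this assay is expected, an at least 2.5-fold lower number from compound 2 to compound 3 (0.39 log units; beyond the scatter). Compound 3 is estimated at 12000 nM, with an expected range from 4000 nM to 30000 nM.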

Compound 3, half-maximal inhibitory concentration: 12900 nM
Beside the measured number, compound 3's estimate is 1.1-fold (0.03 log units) below it; the measured number falls inside the stated range.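

In this assay, the salicylate-bearing side of the series now shows that a substituent on this aromatic carbon can bring a compound back from the limit to a measurable value: an at least 2.3-fold lower number from compound 2 to compound 3 (0.36 log units; beyond the scatter). From the compounds shown here alone, the true size of this step stays open, as compound 2 has only a limit: the limit of > 30000 nM in this assay, at which 1 of the 3 values shown sits.

Going by these compounds, whether the difluoro pattern matters, or any ring at this carbon would do, stays open; an unsubstituted phenyl, an amine or a carboxylic acid here would test this. Also open, on these data alone, is how 2,4-difluorophenyl behaves in the core of compound 1.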